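Chlorine Placement on the Aryl Ring: Compound 2 to Compound 3

The source may hold more compounds than are shown below. What is called first, only, known or untested is meant among the compounds shown, and "the series" means these compounds.

Compound 1 `O=C(N/N=C/c1ccc(F)cc1)c1cccnc1Nc1cccc(C(F)(F)F)c1`: 41.2%
Compound 2 `O=C(N/N=C/c1cccc(Cl)c1)c1cccnc1Nc1cccc(C(F)(F)F)c1`: 63.5%

Of the compounds shown here, two have so far been measured in a functional assay on the whole organism (strain Wistar) for inhibition, with Rattus norvegicus as the target, read by paw edema, with a stated time of 2 h, at a dose of 10 mg/kg by the intraperitoneal route; a lower number here means less inhibition, a higher number more inhibition at the dose given (going by the name of the read-out). Compound 1 gives 41.2% in this assay, and compound 2 gives 63.5%. For the measured compounds named here, compound 2 stands highest of the two numbers, set apart by the only measured step, a number 22.3 percentage points higher from compound 1 to compound 2 (beyond the scatter).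

Compound 3 `O=C(N/N=C/c1ccc(Cl)cc1)c1cccnc1Nc1cccc(C(F)(F)F)c1` differs from compound 2 by 4-chlorophenyl in place of 3-chlorophenyl on a carbon with a double bond to nitrogen. Going by the values given here, only that one step bears on this change, and it altered both the halogen and its place at once, so it speaks to the new change only indirectly: the chlorine is kept, while the position returns to that of compound 1. Among the compounds with values here, with no step isolating either factor, a modest downward movement in this assay, or none beyond the scatter, is expected. Compound 3 is therefore estimated at 53%, within 36% to 70%, which corresponds to an expected step of a number 10.5 percentage points lower from compound 2 to compound 3 (beyond the scatter).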

Compound 3, a percentage reported as inhibition, in the whole organism at one dose (the size of the read-out at that dose, not a potency): 52.8%
Compound 3: middle estimate off by 0.2 percentage points, on the high side; the measured number falls inside the stated range.
By their numbers in this assay, from the lowest: compound 1; then compound 3; then compound 2.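

Compound 3 separates the two things that the earlier step had changed together. Keeping the chlorine and moving only its place, 4-chlorophenyl in place of 3-chlorophenyl, gives a number 10.7 percentage points lower from compound 2 to compound 3 (beyond the scatter) in this assay, while keeping the place and exchanging only the halogen, chloro in place of fluoro on an aromatic carbon, gives a number 11.6 percentage points higher from compound 1 to compound 3 (beyond the scatter), so both the halogen and its place on this ring bear on the read-out, and compound 2 remains highest of the compounds shown. Nothing available gives a reason for either step.

As far as these compounds go, it remains open whether a 3-fluorophenyl group would follow the same order, and whether a methoxy group or an amine on this phenyl ring would read above or below compound 2. The trifluoromethyl group and the rest of the shared core stay fixed throughout, so these steps say nothing about changes there.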